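Changing the aryl group of compound 2

The source may report more compounds than this note shows. Statements on the series, on what has been measured and on what is new or still open speak of the compounds shown alone.

Compound 1 `CCOc1ccc(-c2cc(=O)c3c(o2)C(CC)(CC)C(=O)C(CC)=C3O)cc1`: > 52.4 uM (a limit of the assay)
Compound 2 `CCC1=C(O)c2c(oc(-c3ccc(O)c(C)c3C)cc2=O)C(CC)(CC)C1=O`: 6.5 uM

In a functional assay on KB cells (Homo sapiens) for antiproliferative activity, read by sulforhodamine B assay, with a stated time of 3 days (on this read-out higher numbers stand for an effect only at larger amounts of compound and lower numbers for an effect already at smaller amounts), compound 2 gives 6.5 uM, the only actual number shown so far. The value of compound 1, > 52.4 uM, is a limit of the assay.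

Compound 3 `CCC1=C(O)c2c(oc(-c3cc(C)cc(C)c3)cc2=O)C(CC)(CC)C1=O` has yet to be measured. It carries 3,5-dimethylphenyl in place of 4-hydroxy-2,3-dimethylphenyl on an aromatic carbon, next to the ring oxygen (3,5-dimethylphenyl in place of 4-hydroxy-2,3-dimethylphenyl on an aromatic carbon).

Going by the values given here, one measured step bears on this change, as it also replaces the aryl group: an at least 8.0-fold lower number from compound 1 to compound 2 (0.90 log units; beyond the scatter). This shows that the choice of aryl group can matter in this assay. However, that step involves a different pair of groups, and its full size is unknown, given (the limit of > 52.4 uM in this assay, at which 1 of the 2 values shown sits). Among the compounds with values here, no measured step shows what removing the hydroxy group alone does, so the direction remains open.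

The likeliest outcome is therefore a value near that of compound 2 at 6.5 uM, with a wide margin on either side. The expected change is a 1.2-fold higher number from compound 2 to compound 3 (0.09 log units; within the scatter). For compound 3, the estimated value is 8 uM, with an expected range of 2.5 uM to 30 uM.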

Compound 3, concentration for half-maximal effect: 45.5 uM
Compound 3: middle estimate off by 5.7-fold (0.75 log units), on the low side, and the stated range ends below it.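

Replacing 4-hydroxy-2,3-dimethylphenyl with 3,5-dimethylphenyl gives a 7.0-fold higher number from compound 2 to compound 3 (0.85 log units; beyond the scatter) in this assay. This shows that the aryl group at this position changes the result even between two actual numbers, and not only in a comparison against a limit, so compound 2 holds a clear lead over compound 3 on this read-out. Compound 1 gives > 52.4 uM, a limit of the assay. Replacing 4-ethoxyphenyl with 3,5-dimethylphenyl gives an at least 1.1-fold lower number from compound 1 to compound 3 (0.06 log units; that floor lies within the scatter), and the full size of this step stays unknown: the limit of > 52.4 uM in this assay, at which 1 of the 3 values shown sits.

The change from compound 2 to compound 3 removes the hydroxy group and also moves the methyl groups, and no compound shown differs in only one of these respects, so it remains open which of the two accounts for the step. Also open, going by these compounds, is how this position would respond to an aryl group bearing an amine, a carboxylic acid or a longer chain, and whether the ethyl groups on the shared core contribute to the result in this assay.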